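The compounds below may be only part of what the source reports. "The series", "measured", "known", "first", "only" and "open" are said of these compounds alone.

The three measured compounds share one core, and each carries an aromatic arm joined through an amine to a chain. In a functional assay on Capan-2 cells (Homo sapiens) for inhibition, read by MTT assay, with a stated time of 72 h (on this read-out lower numbers stand for stronger inhibition of growth and higher numbers for weaker inhibition of growth), compound 1 `O=S(=O)(NCCCNCC1COc2ccccc2O1)c1cc(C(F)(F)F)cc(C(F)(F)F)c1` gives 2500 nM, the second highest of the three numbers. In this assay compound 2 `O=S(=O)(NCCCNCc1ccc(-c2ccccc2)cc1)c1cc(C(F)(F)F)cc(C(F)(F)F)c1` gives 2200 nM, a value within the scatter of compound 1, so no order between the two can be claimed. Compound 3 `CC(C)(C)c1ccc(CNCCNS(=O)(=O)c2cc(C(F)(F)F)cc(C(F)(F)F)c2)cc1` gives 13000 nM, a number beyond the scatter above compound 1; compound 3 also differs in its chain, so that gap cannot be laid on a single change. Compound 4 `O=S(=O)(NCCCNCc1cccc(Cl)c1)c1cc(C(F)(F)F)cc(C(F)(F)F)c1` has not been measured. It differs from compound 1 by 3-chlorophenyl in place of 2,3-dihydro-1,4-benzodioxin-2-yl on a saturated chain carbon bound to an amine nitrogen. For the measured compounds named here, no measured pair shows this exact exchange. Because compound 2, with a different aromatic arm, gives 2200 nM close to compound 1, another aromatic arm is expected to leave the number roughly in place. The expected step is no change at the digits printed from compound 1 to compound 4 (within the scatter), within the scatter. Compound 4 is therefore estimated at 2500 nM, with a range from 900 nM to 7000 nM.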

Compound 4, concentration for 50% growth inhibition: 8000 nM
The estimate for compound 4 lay 3.2-fold (0.51 log units) below the measured number; measured number outside the range, above it.
By their numbers in this assay, from the lowest: compounds 2 and 1 (each within the scatter of the next); then compounds 4 and 3 (each within the scatter of the next).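

Putting 3-chlorophenyl in place of 2,3-dihydro-1,4-benzodioxin-2-yl on a saturated chain carbon bound to an amine nitrogen gives, in this assay, a 3.2-fold higher number from compound 1 to compound 4 (0.51 log units; beyond the scatter), a modest step, but the first here that rests on a change in one place alone. This place is therefore not indifferent to the arm it carries, and growth inhibition is weaker with 3-chlorophenyl than with the group it replaces. The exchange removes a non-aromatic ring and its oxygen atoms and brings in a chlorine, and nothing available explains the step.

Whether the chlorine, the lost ring or the lost oxygen atoms account for the difference stays open. A plain phenyl or a methoxyphenyl at this place would be needed to pull these apart.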